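The compounds below may be only part of what the source reports. "The series", "measured", "known", "first", "only" and "open" are said of these compounds alone.

Of the compounds shown here, three have been measured in a functional assay on HepG2 cells (Homo sapiens) for cytotoxicity, read by MTT assay, with a stated time of 72 h; on this read-out higher numbers stand for weaker inhibition of growth and lower numbers for stronger inhibition of growth. Compound 1 `CS/C(=N\C(=O)c1csc([N+](=O)[O-])c1)NC(=O)c1csc([N+](=O)[O-])c1` gives 63400 nM. Compound 2 `CS/C(=N\C(=O)c1ccco1)NC(=O)c1ccco1` reaches only a limit of the assay, > 100000 nM, so no number is known for it. Compound 3 `C[Se]/C(=N\C(=O)c1cccs1)NC(=O)c1cccs1` gives 630 nM, the lowest of the two numbers shown, and its distance from compound 1 lies beyond the usual scatter of repeated measurements.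

Compound 4 `CS/C(=N\C(=O)c1cccs1)NC(=O)c1cccs1` has not yet been measured. It differs from compound 3 in one place: a group of 2 heavy atoms (1 carbon, 1 sulfur; no ring) in place of a group of 2 heavy atoms (1 carbon, 1 selenium; no ring), on a carbon with a double bond to nitrogen. The two nitrogen-bearing arms on the shared core stay the same; only the small group on the central carbon changes. For the measured compounds named here, no measured pair of compounds shows this exact change, so its size cannot be read from the data. Compound 1 and compound 2 both carry the methylsulfanyl group and both sit at weak or unmeasurable inhibition, though with other rings, so compound 4 is expected to inhibit growth less strongly than compound 3, the expected step being a 9.5-fold higher number from compound 3 to compound 4 (0.98 log units; beyond the scatter). For compound 4 the estimated value in this assay is 6000 nM, within a range from 1200 nM to 40000 nM.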

Compound 4, concentration for 50% growth inhibition: > 100000 nM
Compound 4 ended at the assay's limit; the forecaster's own chance of this, stated with the estimate: 15%; at least 16-fold (1.22 log units) between middle value and limit.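

In this assay, putting methylsulfanyl in place of the group of 1 carbon and 1 selenium, on a carbon with a double bond to nitrogen, gives an at least 150-fold higher number from compound 3 to compound 4 (2.20 log units; beyond the scatter), while the two arms stay the same. Compound 4 stands at a limit of the assay, > 100000 nM, and not at a true number. This is the first direct evidence that this one small group can decide whether growth inhibition is detected at all on this shared core, though the size of the step is only a lower bound: the limit of > 100000 nM in this assay, at which 2 of the 4 values shown sit.

From the compounds shown here alone, whether the selenium-bearing group would bring the same gain with the arms of compound 1 or compound 2 remains open. So does the outcome with other groups on that carbon, such as an amine or a longer chain on the selenium.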